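Compound 4 and the shift to 3-aminophenyl

The compounds below may be only part of what the source reports. "The series", "measured", "known", "first", "only" and "open" are said of these compounds alone.

Compound 1 `Nc1cccc(Nc2nc3ccccc3nc2S(=O)(=O)c2ccccc2)c1` gives 1750 nM
Compound 2 `Nc1cccc(Nc2nc3ccccc3nc2S(=O)(=O)c2ccc(Br)cc2)c1` gives 1370 nM
Compound 3 `COc1ccc(Nc2nc3ccccc3nc2S(=O)(=O)c2ccc(F)cc2)cc1` gives 1200 nM

All three values come from a functional assay on HL-60 cells (Homo sapiens) for cytotoxicity, read by MTT assay, with a stated time of 72 h; on this read-out lower numbers stand for stronger inhibition and higher numbers for weaker inhibition. Compound 3 lies within the scatter of both compound 1 and compound 2, so the three cannot be ranked. In compound 4 `Nc1cccc(Nc2nc3ccccc3nc2S(=O)(=O)c2ccc(F)cc2)c1`, 3-aminophenyl takes the place of 4-methoxyphenyl on a nitrogen on an aromatic ring (3-aminophenyl in place of 4-methoxyphenyl on a nitrogen on an aromatic ring). For the measured compounds named here, no measured step covers this exchange directly. Going by the values given here, the only measured step, a 1.3-fold lower number from compound 1 to compound 2 (0.11 log units; within the scatter), is bromo in place of hydrogen on an aromatic carbon, in compounds that already carry 3-aminophenyl, and it stays within the scatter. No change beyond the scatter is therefore expected in this assay, and the estimated step is a 1.3-fold higher number from compound 3 to compound 4 (0.10 log units; within the scatter). For compound 4 the estimate is 1500 nM, with an expected range of 700 nM to 3200 nM.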

Compound 4, half-maximal inhibitory concentration: 4040 nM
The estimate for compound 4 lay 2.7-fold (0.43 log units) below the measured number; measured number outside the range, above it.
By their numbers in this assay, from the lowest: compounds 3, 2 and 1 (each within the scatter of the next); then compound 4.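

In this assay, for the compounds shown here, 3-aminophenyl in place of 4-methoxyphenyl on a nitrogen on an aromatic ring gives a step beyond the scatter (a 3.4-fold higher number from compound 3 to compound 4 (0.53 log units; beyond the scatter)), so this position can move the number, which the earlier compounds did not show. With 3-aminophenyl held in place, fluoro also separates from both hydrogen (a 2.3-fold higher number from compound 1 to compound 4 (0.36 log units; beyond the scatter)) and bromo (a 2.9-fold higher number from compound 2 to compound 4 (0.47 log units; beyond the scatter)), although bromo and hydrogen stay within the scatter of each other. Nothing shown gives a reason for these steps. The compounds leave open how plain phenyl on that nitrogen would compare, and whether chloro or methyl on the aromatic carbon would follow fluoro or bromo.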